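Methyl on the chlorophenyl ring across two nitrobenzyl cores

The source may hold more compounds than are shown below. What is called first, only, known or untested is meant among the compounds shown, and "the series" means these compounds.

Two cores are in hand. Compound 1 `O=[N+]([O-])c1ccc(Cn2cc(COc3ccc(Cl)cc3)nn2)cc1` and compound 2 `O=[N+]([O-])c1cccc(Cn2cc(COc3ccc(Cl)cc3)nn2)c1` are built from the same atoms joined differently; the difference between the two cores is not broken down here. In a physicochemical assay, read by spectrophotometry, with a stated time of 30 min (on this read-out higher numbers stand for weaker inhibition and lower numbers for stronger inhibition), compound 1 gives 24.2 ug/mL and compound 2 gives 21.3 ug/mL, a pair of numbers that sit close together.

Compound 3 `Cc1cc(OCc2cn(Cc3ccc([N+](=O)[O-])cc3)nn2)ccc1Cl` differs from compound 1 in one place: methyl in place of hydrogen on an aromatic carbon. In this assay compound 3 gives 13.4 ug/mL, so the step measured is a 1.8-fold lower number from compound 1 to compound 3 (0.26 log units; within the scatter).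

Compound 4 `Cc1cc(OCc2cn(Cc3cccc([N+](=O)[O-])c3)nn2)ccc1Cl` has not yet been measured. It differs from compound 2 in one place: methyl in place of hydrogen on an aromatic carbon. The words describing this change match those for the change from compound 1 to compound 3 in every respect, including where the methyl sits, so the same change is now to be read on the second core.

Within the data shown here, the only guide is the single step already seen. A step of a 1.6-fold lower number from compound 2 to compound 4 (0.21 log units; within the scatter) is expected from compound 2 to compound 4, because the parallel change gave a 1.8-fold lower number from compound 1 to compound 3 (0.26 log units; within the scatter) and nothing in hand argues for a different size on the second core. On that basis compound 4 is expected to give about 13 ug/mL in this assay, with a likely range from 8 ug/mL to 22 ug/mL. Whether the step will clear the usual scatter, as the earlier one did not, cannot be decided from one example.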

Compound 4, half-maximal inhibitory concentration: 15.6 ug/mL
Compound 4: middle estimate off by 1.2-fold (0.08 log units), on the low side, and the stated range covers the measured number.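

In this assay, the change from 4-chlorophenyl to 4-chloro-3-methylphenyl now reads as a 1.4-fold lower number from compound 2 to compound 4 (0.14 log units; within the scatter) on the core of compound 2, and the matching change reads as a 1.8-fold lower number from compound 1 to compound 3 (0.26 log units; within the scatter) on the core of compound 1. Both steps point the same way and both lie within the usual scatter, so the two cores give no sign that the change behaves differently from one to the other, but neither step establishes a real effect of the methyl on its own. Two pairs on two closely related cores say nothing about other cores in the series, and no accompanying measurement offers an explanation for either step.

The compounds shown leave open whether any substitution at this place, ortho to the chloro group, can produce a step that clears the scatter, for instance an amine, a carboxylic acid or a longer chain such as ethyl in place of the methyl. Also open, on these data alone, is whether the methyl step would read the same on the ring without its chloro group, a question neither pair can answer.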